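Sulfonyl substituent variation in the aryl alkyne acid series

The compounds below may be only part of what the source reports. "The series", "measured", "known", "first", "only" and "open" are said of these compounds alone.

Measured in an assay on CHO cells for displacement of a labelled ligand from prostaglandin D2 receptor 2 (Homo sapiens), read by scintillation counting; on this read-out higher numbers stand for weaker inhibition and lower numbers for stronger inhibition:

compound 1 `COCCN(C)S(=O)(=O)c1ccc(C)c(C#Cc2cc(Cl)ccc2OCC(=O)O)c1` gives 4.1 nM
compound 2 `Cc1ccc(S(=O)(=O)N2CCN(C)CC2)cc1C#Cc1cc(Cl)ccc1OCC(=O)O` gives 21 nM
compound 3 `CCS(=O)(=O)c1ccc(C)c(C#Cc2cc(Cl)ccc2OCC(=O)O)c1` gives 8.6 nM

Compound 3 stands second highest of the three numbers: a 2.1-fold higher number from compound 1 to compound 3 (0.32 log units; beyond the scatter) and a 2.4-fold lower number from compound 2 to compound 3 (0.39 log units; beyond the scatter), both beyond the scatter and both modest.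

Compound 4 `Cc1ccc(S(=O)(=O)N(C)C(C)C)cc1C#Cc1cc(Cl)ccc1OCC(=O)O` differs from compound 3 by isopropyl(methyl)amino in place of ethyl on a sulfonyl sulfur. Both measured steps bear on this change, since each exchanges an amino group on the sulfonyl sulfur for ethyl: the group of compound 1, which has no ring, sits at the lower number, while the ring-bearing group of compound 2 sits at the higher one. Isopropyl(methyl)amino has no ring, so compound 4 is expected to move toward compound 1, a modest step down in this assay, a 1.7-fold lower number from compound 3 to compound 4 (0.24 log units; within the scatter). Compound 4 is estimated at 5 nM, within 2 nM to 13 nM.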

Compound 4, inhibition constant: 3.8 nM
Estimate against measurement, compound 4: 1.3-fold (0.12 log units) above, within the range that was stated.
By their numbers in this assay, from the lowest: compounds 4 and 1 (each within the scatter of the next); then compound 3; then compound 2.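

Isopropyl(methyl)amino on the sulfonyl sulfur gives a lower number than ethyl (a 2.3-fold lower number from compound 3 to compound 4 (0.35 log units; beyond the scatter)) and than 4-methylpiperazin-1-yl (a 5.5-fold lower number from compound 2 to compound 4 (0.74 log units; beyond the scatter)). With isopropyl in place of 2-methoxyethyl on the sulfonamide nitrogen (a 1.1-fold lower number from compound 1 to compound 4 (0.03 log units; within the scatter)), this assay does not separate compound 1 and compound 4, so these two ringless amino groups read alike at this position. No measured evidence accounts for these steps.

Still open, as far as these compounds go, is whether the ring of compound 2 or its second ring nitrogen goes with its higher number. A piperidine on the sulfonyl sulfur would separate the two.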